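Urea aryl swap in a chloropyrazine series: compound 4

This account rests on a few compounds, and the source may have more. Where it says the series, first, only, none or still open, it means among the compounds named here.

Three ureas built on a shared core have been measured in a functional assay on MGC-803 cells (Homo sapiens) for antiproliferative activity, read by MTT assay, with a stated time of 48 h; a lower number here means a stronger inhibitor, a higher number a weaker inhibitor. Compound 1 `Cc1ccc(NC(=O)Nc2cccc(CNc3nccnc3Cl)c2)cc1C` gives 9870 nM. Compound 2 `O=C(Nc1cccc(CNc2nccnc2Cl)c1)Nc1ccccc1Cl` gives 7130 nM, and compound 3 `O=C(Nc1cccc(CNc2nccnc2Cl)c1)Nc1ccccc1F` gives 6440 nM. Compound 2 stands second highest of the three numbers, though its steps to both neighbours are within the scatter: a 1.4-fold lower number from compound 1 to compound 2 (0.14 log units; within the scatter) and a 1.1-fold lower number from compound 2 to compound 3 (0.04 log units; within the scatter). The other step measured, a 1.5-fold lower number from compound 1 to compound 3 (0.19 log units; within the scatter), is also within the scatter.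

Compound 4 `Cc1ccc(NC(=O)Nc2cccc(CNc3nccnc3Cl)c2)c(C)c1` has not yet been measured. Its difference from compound 2 is 2,4-dimethylphenyl in place of 2-chlorophenyl on an amide-type nitrogen. Among the compounds with values here, the steps that bear on it are the exchange of a dimethylphenyl for a halophenyl on the same nitrogen in a 1.4-fold lower number from compound 1 to compound 2 (0.14 log units; within the scatter) and a 1.5-fold lower number from compound 1 to compound 3 (0.19 log units; within the scatter); neither moved the number beyond the scatter. The present change runs the other way, from a halophenyl back to a dimethylphenyl, so no step beyond the scatter is expected in this assay. Compound 4 is therefore expected to give about 8500 nM, between 4000 nM and 18000 nM, a step of a 1.2-fold higher number from compound 2 to compound 4 (0.08 log units; within the scatter).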

Compound 4, half-maximal inhibitory concentration: 10100 nM
Estimate against measurement, compound 4: 1.2-fold (0.07 log units) below; measured number inside the range.
By their numbers in this assay, from the lowest: compounds 3, 2, 1 and 4 (each within the scatter of the next).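

In this assay, the exchange of a halophenyl for a dimethylphenyl on the amide-type nitrogen now reads within the scatter in this direction too, for the chloro compound, a 1.4-fold higher number from compound 2 to compound 4 (0.15 log units; within the scatter), and for the fluoro compound, a 1.6-fold higher number from compound 3 to compound 4 (0.20 log units; within the scatter). The new compound also shows that the arrangement of the two methyl groups does not separate the dimethylphenyl ureas in this assay, a 1.0-fold higher number from compound 1 to compound 4 (0.01 log units; within the scatter). No measurement is at hand to explain why these numbers stay so close.

All four ureas carry only methyl, chloro or fluoro on this aryl ring, and all four numbers lie within the scatter of the next. As far as these compounds go, whether an amine or a carboxylic acid on that ring would move the number beyond the scatter remains open.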